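The compounds below may be only part of what the source reports. "The series", "measured", "known", "first", "only" and "open" are said of these compounds alone.

Compound 1 `O=C(CBr)Nc1ccc(C(=O)/C=C/c2ccc(Cl)cc2)cc1` gives 59% in a functional assay on the whole organism (strain albino) for inhibition, with Rattus norvegicus as the target, read by paw edema, with stated times of 30 min and 3 h, at a dose of 100 mg/kg by the oral route; a higher number here means more inhibition at the dose given (going by the name of the read-out), a lower number less inhibition. Compound 2 `O=C(CO[N+](=O)[O-])Nc1ccc(C(=O)/C=C/c2ccc(Cl)cc2)cc1` gives 69% in this assay, and compound 3 `CC(Br)C(=O)Nc1ccc(C(=O)/C=C/c2ccc(Cl)cc2)cc1` gives 59%. The change nitrooxy in place of bromo on a saturated chain carbon bound to a carbonyl carbon made a number 10 percentage points higher from compound 1 to compound 2 (within the scatter), and compound 3 differs from compound 1 by no change at the digits printed from compound 1 to compound 3 (within the scatter).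

Compound 4 `CC(O[N+](=O)[O-])C(=O)Nc1ccc(C(=O)/C=C/c2ccc(Cl)cc2)cc1` has not been measured. It differs from compound 3 by nitrooxy in place of bromo on a saturated chain carbon bound to a carbonyl carbon and a saturated chain carbon. The cores of compound 3 and compound 1 differ by methyl in place of hydrogen on a saturated chain carbon bound to a bromine atom and a carbonyl carbon. The place of the change is not identical: in compound 3 the saturated chain carbon is bound to a carbonyl carbon and a saturated chain carbon, whereas in compound 1 it is bound only to a carbonyl carbon, so this is the same kind of change rather than the same change.

For compound 4 a step of a number 8 percentage points higher from compound 3 to compound 4 (within the scatter) is expected, because the like change gave a number 10 percentage points higher from compound 1 to compound 2 (within the scatter) from compound 1 at 59%. The estimate for compound 4 is therefore 67%, spanning 52% to 80%.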

Compound 4, a percentage reported as inhibition, in the whole organism at one dose (the size of the read-out at that dose, not a potency): 62%
Compound 4: middle estimate off by 5 percentage points, on the high side; low and high end bracket the measured number.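

In this assay, nitrooxy in place of bromo on the core of compound 3 gave a number 3 percentage points higher from compound 3 to compound 4 (within the scatter), and this agrees with the same change on the core of compound 1: the same change on two cores in this assay, a number 10 percentage points higher (within the scatter) from compound 1 to compound 2 and a number 3 percentage points higher (within the scatter) from compound 3 to compound 4, 7 percentage points apart, within the scatter of two such steps. Methyl in place of hydrogen gave a number 7 percentage points lower from compound 2 to compound 4 (within the scatter), and this too agrees with its earlier counterpart: the same change on two cores in this assay, no change at the digits printed (within the scatter) from compound 1 to compound 3 and a number 7 percentage points lower (within the scatter) from compound 2 to compound 4, 7 percentage points apart, within the scatter of two such steps. The full replacement of bromomethyl by 1-(nitrooxy)ethyl gave a number 3 percentage points higher from compound 1 to compound 4 (within the scatter), so with every step within the scatter, the series shows that neither change reads differently on the two cores, but not that either has a real effect that carries over.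

The compounds shown leave open how an amine, a carboxylic acid or a longer chain at this place would read in this assay.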